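Adding a Methoxy Group to Compound 3

This account rests on a few compounds, and the source may have more. Where it says the series, first, only, none or still open, it means among the compounds named here.

Compound 1 `COc1ccc(/C=N/n2c(C)nc3c(cnn3-c3ccc(Cl)cc3)c2=O)cc1` gives 38600 nM in a functional assay on MCF7 cells (Homo sapiens) for cytotoxicity, read by colorimetric assay and sulforhodamine B assay, with a stated time of 48 h; on this read-out lower numbers stand for stronger inhibition and higher numbers for weaker inhibition. Compound 2 `COc1ccc(/C=N/n2c(C)nc3c(cnn3-c3ccc(Cl)cc3)c2=O)cc1OC` carries methoxy in place of hydrogen on an aromatic carbon and gives 25000 nM in this assay, so that a 1.5-fold lower number from compound 1 to compound 2 (0.19 log units; within the scatter). Compound 3 `COc1ccc(/C=N/n2c(C)nc3c(cnn3S(=O)(=O)c3ccc(Cl)cc3)c2=O)cc1OC` gives 33600 nM, and the step from it reads a 1.3-fold higher number from compound 2 to compound 3 (0.13 log units; within the scatter). The difference between the cores of compound 1 and compound 3 is not broken down here. Compound 4 `COc1cc(/C=N/n2c(C)nc3c(cnn3S(=O)(=O)c3ccc(Cl)cc3)c2=O)cc(OC)c1OC` has not been measured. It differs from compound 3 by methoxy in place of hydrogen on an aromatic carbon, the same kind of change as that made from compound 1 to compound 2, though the place here is also meta to a methoxy group. Because a 1.5-fold lower number from compound 1 to compound 2 (0.19 log units; within the scatter) stayed within the scatter, the step expected for compound 4 is a 1.3-fold lower number from compound 3 to compound 4 (0.11 log units; within the scatter). Compound 4 is thus estimated at 26000 nM, between 12000 nM and 60000 nM.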

Compound 4, half-maximal inhibitory concentration: 27800 nM
Compound 4: middle estimate off by 1.1-fold (0.03 log units), on the low side; measured number inside the range.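

In this assay, methoxy in place of hydrogen gives a 1.2-fold lower number from compound 3 to compound 4 (0.08 log units; within the scatter). Set beside the earlier case, the same kind of change shows no difference between the two cores: the same change on two cores in this assay, a 1.5-fold lower number (0.19 log units; within the scatter) from compound 1 to compound 2 and a 1.2-fold lower number (0.08 log units; within the scatter) from compound 3 to compound 4, 1.3-fold (0.11 log units) apart, within the scatter of two such steps. This shows that the change carries from the core of compound 1 to the core of compound 3 without a shift that can be told from scatter, but it does not show that methoxy has any effect on either core, and two cores cannot speak for the whole series.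

Methoxy is the only group shown entering at these places, so it remains open whether a hydroxy group, an amine or a carboxylic acid there would give a step beyond the scatter.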